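A second methoxy group on compound 2

The source may report more compounds than this note shows. Statements on the series, on what has been measured and on what is new or still open speak of the compounds shown alone.

Compound 1 `COc1ccccc1CNc1ncnc2c1ncn2C1CCCCO1`: > 100000 nM
Compound 2 `COc1cccc(CNc2ncnc3c2ncn3C2CCCCO2)c1`: > 100000 nM
Compound 3 `COc1cc(CNc2ncnc3c2ncn3C2CCCCO2)ccc1O`: > 100000 nM

These three entries come from an ADME assay on BJ cells (Homo sapiens) for cytotoxicity, read by MTT assay, with a stated time of 72 h (a lower number here means a stronger inhibitor, a higher number a weaker inhibitor), and each one is a limit of the assay, not a number. Compound 2 stands at > 100000 nM, which is such a limit. Within the data shown here, the series so far offers only (the limit of > 100000 nM in this assay, at which 3 of the 3 values shown sit).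

The step followed here leads to compound 4 `COc1ccc(OC)c(CNc2ncnc3c2ncn3C2CCCCO2)c1`, which has not yet been measured. Its difference from compound 2 is methoxy in place of hydrogen on an aromatic carbon, ortho to a large group and para to a methoxy group.

The closest measured change is a step that the two limits leave unreadable from compound 2 to compound 3, where hydroxy replaces hydrogen on an aromatic carbon. Moving the methoxy group gave a step that the two limits leave unreadable from compound 1 to compound 2. Neither step has a size that can be read. Compound 3 carries the added hydroxy and still gives > 100000 nM, again a limit.

On that ground, no step beyond the scatter is expected in this assay, and a further limit is the likeliest report. The expected step, as estimated, is a step that the limit leaves unreadable from compound 2 to compound 4. Compound 4 is expected at 120000 nM, with an estimated range of 50000 nM to 300000 nM.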

Compound 4, half-maximal inhibitory concentration: > 100000 nM
Compound 4: only a limit was reported; the forecaster's own chance of this, stated with the estimate: 85%; the middle value lies beyond the limit too.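

In this assay compound 4 gives > 100000 nM, which is a limit of the assay and not a number. Among these compounds, no step to compound 4 can be read from either compound 1 or compound 2, because every value is a limit: the limit of > 100000 nM in this assay, at which 4 of the 4 values shown sit. The compounds shown leave open where any of them would give an actual number in this assay, and so what the added methoxy does there.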